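Thiazole in place of pyrimidine on the imidazoline ether core

The compounds below may be only part of what the source reports. "The series", "measured", "known", "first", "only" and "open" are said of these compounds alone.

Measured so far in a functional assay for activation of Alpha-1D adrenergic receptor (Homo sapiens), read by calcium flux; a higher number here means that more compound is needed for the effect, a lower number that less compound is needed:
compound 1 `c1cncc(-c2ccccc2OCC2=NCCN2)c1` gives 158 nM;
compound 2 `c1ccc(-c2ccncn2)c(OCC2=NCCN2)c1` gives < 100000 nM, a limit of the assay and not a number;
compound 3 `c1ccc(-c2nccs2)c(OCC2=NCCN2)c1` gives 31.6 nM.

Compound 2 thus stands only at a limit in this assay, without a number of its own. Compound 4 `Cc1csc(-c2ccccc2OCC2=NCCN2)n1` differs from it in one place: 4-methyl-1,3-thiazol-2-yl in place of pyrimidin-4-yl on an aromatic carbon. The step that the limit leaves unreadable from compound 2 to compound 3 is not readable, since one side is the limit (the limit of < 100000 nM in this assay, at which 1 of the 3 values shown sits). Among the measured compounds shown here, the only readable step with a thiazole entering is a 5.0-fold lower number from compound 1 to compound 3 (0.70 log units; beyond the scatter), a modest change. Compound 4 carries the 4-methyl-1,3-thiazol-2-yl group, so its value is expected near that of compound 3, which is 31.6 nM. For compound 4 the estimate in this assay is 40 nM, between 10 nM and 160 nM, which as a step means a step that the limit leaves unreadable from compound 2 to compound 4.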

Compound 4, half-maximal effective concentration: < 100000 nM
Compound 4: a limit, no number; the forecaster's own chance of this, stated with the estimate: 5%; the middle value does not contradict the limit.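

Compound 4 gives < 100000 nM, a limit and not a number. Among the compounds shown here, no step to compound 4 from compound 1, compound 2 or compound 3 can therefore be read. The compounds shown leave open how large the effect of methyl in place of hydrogen on an aromatic carbon, between compound 3 and compound 4, really is.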